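The compounds below may be only part of what the source reports. "The series", "measured", "known", "first", "only" and "open" are said of these compounds alone.

Of the compounds shown here, three have been measured in an in vitro functional assay on HEK285-7 cells for antagonist activity at prostaglandin D2 receptor 2 (Homo sapiens), read by BRET and beta-arrestin recruitment; on this read-out lower numbers stand for smaller maximal responses and higher numbers for larger maximal responses. Compound 1 `COc1ccc(OC)c(-c2nc(C(c3ccccc3)c3ccccc3)sc2CC(=O)O)c1` gives 80% in this assay, compound 2 `O=C(O)Cc1sc(Cc2ccccc2)nc1-c1ccc(Cl)cc1` gives 50%, and compound 3 `CS(=O)(=O)Nc1cccc(-c2nc(C(c3ccc(F)cc3)c3ccc(F)cc3)sc2CC(=O)O)c1` gives 80%. Compound 3 thus stands level with compound 1 within the scatter, the two sharing the highest maximal response of the set, and well above compound 2, a gap beyond the scatter. Compound 4 `O=C(O)Cc1sc(C(c2ccc(F)cc2)c2ccc(F)cc2)nc1-c1cc(F)cc(F)c1` differs from compound 3 in a single place: 3,5-difluorophenyl in place of 3-(methanesulfonamido)phenyl on an aromatic carbon. Going by the values given here, no step between measured compounds isolates this exchange. Since compound 1 reaches 80% with a quite different aryl group, the step from compound 3 to compound 4 in this assay is expected to be small, slightly downward or none beyond the scatter, a number 8 percentage points lower from compound 3 to compound 4 (within the scatter). Compound 4 is therefore estimated at 72% in this assay, within a range from 50% to 90%.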

Compound 4, largest response reached (reported as efficacy), in percent of the reference or control that the assay uses: 80%
The estimate for compound 4 lay 8 percentage points below the measured number; measured number inside the range.
By their numbers in this assay, from the lowest: compound 2; then compounds 1, 3 and 4 (each within the scatter of the next).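

In this assay, 3,5-difluorophenyl in place of 3-(methanesulfonamido)phenyl, on the aromatic carbon next to the ring nitrogen, brings no change at the digits printed from compound 3 to compound 4 (within the scatter). Going by these compounds alone, at this position, then, a group without hydrogen-bond donors or acceptors stands in for one that has both, with no step beyond the scatter, a comparison that no earlier pair allowed. Nothing given here explains this result.

On these data alone, it remains open whether the maximal response would hold with an amine or a carboxylic acid on this phenyl ring. As far as these compounds go, whether it would hold with a saturated ring such as cyclohexyl in place of the phenyl ring is equally open.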